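A few compounds are considered here, and "the series" means these few. Any claim that something is new, unique, unknown or untested is made for them only; others in the source may bear on it.

Measured in a functional assay on NCI-H460 cells (Homo sapiens) for cytotoxicity, read by MTT assay, with a stated time of 72 h; a lower number here means a stronger inhibitor, a higher number a weaker inhibitor:
- compound 1 `CC(C)(C)c1[nH]cnc1/C=c1\[nH]c(=O)/c(=C/c2cccc(Oc3ccc(F)cc3)c2)[nH]c1=O`: 4 nM
- compound 2 `O=c1[nH]/c(=C\c2c[nH]cn2)c(=O)[nH]/c1=C\c1cccc(Oc2ccc(F)cc2)c1`: 479 nM
- compound 3 `O=c1[nH]/c(=C\c2ncc[nH]2)c(=O)[nH]/c1=C\c1cccc(Oc2ccc(F)cc2)c1`: > 1000 nM (a limit)

For compound 3 the result is only a limit, > 1000 nM, and not a number.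

Compound 4 `O=c1[nH]/c(=C\c2ccc(Br)o2)c(=O)[nH]/c1=C\c1cccc(Oc2ccc(F)cc2)c1` is still unmeasured. It has 5-bromofuran-2-yl in place of 1H-imidazol-2-yl, on a double-bonded chain carbon bound to an aromatic carbon: 5-bromofuran-2-yl in place of 1H-imidazol-2-yl on a double-bonded chain carbon bound to an aromatic carbon.

For the measured compounds named here, three measured steps concern the group at this place. Changing the attachment of the imidazole gave an at least 2.0-fold higher number from compound 2 to compound 3 (0.31 log units; beyond the scatter). Removing the tert-butyl gave a 120-fold higher number from compound 1 to compound 2 (2.08 log units; beyond the scatter), and the full exchange gave an at least 250-fold higher number from compound 1 to compound 3 (2.39 log units; beyond the scatter). None of these compounds carries a furan or a bromine, so they show only that this place can move the read-out widely.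

Compound 1, with a substituted ring here, reads 4 nM, and the ring entering compound 4 is also substituted. A move to a lower number in this assay is therefore expected, of modest to large size. The expected step is an at least 4.0-fold lower number from compound 3 to compound 4 (0.60 log units; beyond the scatter). For compound 4 the estimated value is 250 nM, with an expected range of 30 nM to 1000 nM.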

Compound 4, half-maximal inhibitory concentration: 361 nM
Estimate against measurement, compound 4: 1.4-fold (0.16 log units) below; measured number inside the range.
By their numbers in this assay, from the lowest: compound 1; then compounds 4 and 2 (each within the scatter of the next). At a limit, above all of these: compound 3.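

The exchange of 1H-imidazol-2-yl for 5-bromofuran-2-yl gives an at least 2.7-fold lower number from compound 3 to compound 4 (0.44 log units; beyond the scatter) in this assay, so a hydrogen-bond donor on this ring is not needed for a measurable read-out in this series. Compound 3 stands only at a limit: the limit of > 1000 nM in this assay, at which 1 of the 4 values shown sits.

Against the 1H-imidazol-4-yl ring, the bromofuran gives a 1.3-fold lower number from compound 2 to compound 4 (0.12 log units; within the scatter), so the two rings are not separated here, while a 90-fold higher number from compound 1 to compound 4 (1.96 log units; beyond the scatter) shows that a substituted ring at this place does not by itself match the 5-(tert-butyl)-1H-imidazol-4-yl group. The compounds shown leave open whether the bromine contributes to the value of compound 4, and whether the tert-butyl or the imidazole carrying it accounts for the gap to compound 1. A 5-(tert-butyl)furan-2-yl group or a methyl-substituted imidazole at this place would separate these.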